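Acetophenone ethers: sulfonyl to tetrazolylcarbamoyl on the chain

The source may hold more compounds than are shown below. What is called first, only, known or untested is meant among the compounds shown, and "the series" means these compounds.

Measured compounds:
compound 1, `CCc1cc(C(C)=O)c(O)cc1OCCCCCCC(C)(C)C#N`, 65%
compound 2, `CCc1cc(C(C)=O)c(O)cc1OCCCCCC[S+](C)[O-]`, 92%
compound 3, `CCc1cc(C(C)=O)c(O)cc1OCCCCCCS(C)(=O)=O`, 99%

All three share one core and differ only at the end of a saturated chain on an aromatic oxygen. In an assay on isolated protein for inhibition of leukotriene B4 receptor 1 (Homo sapiens), tested at 10 uM (a higher number here means more inhibition at the concentration tested (going by the name of the read-out), a lower number less inhibition), compound 3 gives 99%, the highest of the three numbers. The step of a number 7 percentage points higher from compound 2 to compound 3 (within the scatter) is within the scatter, so compound 2 and compound 3 are not told apart; the step of a number 34 percentage points higher from compound 1 to compound 3 (beyond the scatter) is beyond it.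

Compound 4, `CCc1cc(C(C)=O)c(O)cc1OCCCCCCC(=O)Nc1nn[nH]n1`, is not yet measured. Its change from compound 3 is (2H-tetrazol-5-yl)carbamoyl in place of methylsulfonyl on a saturated chain carbon, six bonds along the chain from an oxygen on an aromatic ring. Both measured steps that end at compound 3, a number 34 percentage points higher from compound 1 to compound 3 (beyond the scatter) and a number 7 percentage points higher from compound 2 to compound 3 (within the scatter), sit at the same chain carbon, and both leave compound 3 as the high end. For the measured compounds named here, no measured step carries a group of this kind into that place, so the direction is open; with compound 3 already near the top of the scale, a step downward beyond the scatter is more likely than one upward. Compound 4 is therefore expected to give about 82%, in the range 50% to 100%, a change of a number 17 percentage points lower from compound 3 to compound 4 (beyond the scatter) that is estimated, not measured.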

Compound 4, a percentage reported as inhibition, at one concentration (the size of the read-out at that concentration, not a potency): 101%
The estimate for compound 4 lay 19 percentage points below the measured number, and the stated range ends below it.
By their numbers in this assay, from the lowest: compound 1; then compounds 2, 3 and 4 (each within the scatter of the next).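

In this assay the step of a number 2 percentage points higher from compound 3 to compound 4 (within the scatter) and the step of a number 9 percentage points higher from compound 2 to compound 4 (within the scatter) show that this chain end takes (2H-tetrazol-5-yl)carbamoyl, with its five-membered aromatic ring and no sulfur, and the number stays with those of the two sulfur-bearing compounds. The step of a number 36 percentage points higher from compound 1 to compound 4 (beyond the scatter) places this group, like the sulfur groups, clear of the 1-cyano-1-methylethyl end, so a sulfur group is not needed for a high number among these compounds. Nothing available accounts for this result.

Going by these compounds, with compounds 2, 3 and 4 so close together at one concentration, this read-out cannot rank them, and their potencies remain open. On these data alone, it also remains open whether a carboxylic acid at the chain end, or a shorter chain carrying the same (2H-tetrazol-5-yl)carbamoyl, would give a similar number.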